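A few compounds are considered here, and "the series" means these few. Any claim that something is new, unique, unknown or untested is made for them only; others in the source may bear on it.

Measured compounds:

compound 1 `CCCCCCC[C@H]1C[C@H](Br)CCN1S(=O)(=O)c1ccc(C)cc1` — > 100000 nM
compound 2 `Cc1ccc(S(=O)(=O)N2CC[C@@H](Br)C[C@@H]2C2CCCCC2)cc1` — > 100000 nM
compound 3 `CCCCCCCC1C=C(Br)CCN1S(=O)(=O)c1ccc(C)cc1` — > 100000 nM

The three compounds share a sulfonamide built on a six-membered ring that carries a bromo group and a large side group, and all were tested in a functional assay on A2780 cells (Homo sapiens) for antiproliferative activity, read by sulforhodamine B assay, with a stated time of 48 h; on this read-out higher numbers stand for weaker inhibition of growth and lower numbers for stronger inhibition of growth. In this assay compound 1 gives > 100000 nM, which is a limit of the measurement and not a number. Compound 2 gives > 100000 nM, again only a limit. Compound 3 gives > 100000 nM, also a limit. The change between the first two is cyclohexyl in place of heptyl on a saturated ring carbon. The result of that change in this assay is a step that the two limits leave unreadable from compound 1 to compound 2, so nothing can be said about whether the heptyl or the cyclohexyl version inhibits growth more strongly. Compound 3 carries a different core from compound 1, with a double bond in the ring; that difference between the two cores is not broken down here.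

Compound 4 `Cc1ccc(S(=O)(=O)N2CCC(Br)=CC2C2CCCCC2)cc1` has not yet been measured. It differs from compound 3 by cyclohexyl in place of heptyl on a saturated ring carbon, the same change as that from compound 1 to compound 2, made on the unsaturated core. Because (the limit of > 100000 nM in this assay, at which 3 of the 3 values shown sit), the step from compound 3 to compound 4 is expected to be a step that the limit leaves unreadable from compound 3 to compound 4, with the outcome most likely reported again as a limit rather than a number. Compound 4 is estimated at 150000 nM, within a range from 60000 nM to 500000 nM.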

Compound 4, concentration for 50% growth inhibition: 44000 nM
Compound 4: the middle estimate sits 3.4-fold (0.53 log units) above what was measured, outside the stated range (below it).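

In this assay, putting cyclohexyl in place of heptyl on the core with a double bond in the ring gives an at least 2.2-fold lower number from compound 3 to compound 4 (0.35 log units; beyond the scatter) and so means stronger inhibition of growth on that core; the sign of the step matters here, since compound 3 gives > 100000 nM as a limit and not a number. As far as these compounds go, the step therefore marks only the smallest change the data allow, and its full size stays unknown. It does not show that the change carries from one core to the other, because the matching step on the saturated core, from compound 1 to compound 2, cannot be read: the limit of > 100000 nM in this assay, at which 3 of the 4 values shown sit.

The compounds shown leave open whether another group in the same place, such as phenyl or a shorter chain like butyl, would push the number lower still on the core with the double bond. They also leave open how much the bromo group contributes to the growth inhibition seen with compound 4, which a chloro group or an amine in its place could help to settle.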